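Trifluoromethyl for trifluoromethoxy in a diarylamine series

The source may hold more compounds than are shown below. What is called first, only, known or untested is meant among the compounds shown, and "the series" means these compounds.

Compound 1 `C=C[C@@](C)(/C=C/c1ccc(Nc2cccc(OC(F)(F)F)c2)cc1)CCC=C(C)C` was tested in a functional assay on HepG2 cells (Homo sapiens) for cytotoxicity, with a stated time of 72 h; a lower number here means that less compound is needed, a higher number that more compound is needed for the effect. In this assay compound 1 gives > 52000 nM, which is a limit of the assay and not a number. Compound 2 `C=C[C@@](C)(/C=C/c1ccc(Nc2ccc(OC(F)(F)F)cc2)cc1)CCC=C(C)C` in this assay gives > 52000 nM, again only a limit. Compound 3 `C=C[C@@](C)(/C=C/c1ccc(Nc2ccc(C(F)(F)F)cc2)cc1)CCC=C(C)C` in this assay gives > 52000 nM, likewise a limit. The change trifluoromethyl in place of trifluoromethoxy on an aromatic carbon gives a step that the two limits leave unreadable from compound 2 to compound 3, since (the limit of > 52000 nM in this assay, at which 3 of the 3 values shown sit). Compound 4 `C=C[C@@](C)(/C=C/c1ccc(Nc2cccc(C(F)(F)F)c2)cc1)CCC=C(C)C` carries the same kind of change, (trifluoromethyl in place of trifluoromethoxy on an aromatic carbon), where the group sits meta to a large group rather than para to a large group; the difference between the cores of compound 1 and compound 2 is not broken down here. He expects a step that the limit leaves unreadable from compound 1 to compound 4, resting on (the limit of > 52000 nM in this assay, at which 3 of the 3 values shown sit). For compound 4 in this assay he estimates 80000 nM.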

Compound 4, half-maximal effective concentration: > 52000 nM
Compound 4 ended at the assay's limit; the forecaster's own chance of this, stated with the estimate: 85%; the middle value does not contradict the limit.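

No step can be read from compound 1 to compound 4, since both stop at a limit of this assay. The compounds shown leave open whether trifluoromethyl for trifluoromethoxy changes cytotoxicity at all, since none gives a number: the limit of > 52000 nM in this assay, at which 4 of the 4 values shown sit.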